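The source may report more compounds than this note shows. Statements on the series, on what has been measured and on what is new or still open speak of the compounds shown alone.

Working notes on the series. Three compounds have numbers in a functional assay on the whole organism for antagonist activity, with Rattus norvegicus as the target; on this read-out higher numbers stand for an effect only at larger amounts of compound and lower numbers for an effect already at smaller amounts. Compound 1 `CN(C)c1ncnc2c1ncn2Cc1cccc(C#N)c1` gives 13 mg/kg in this assay. Compound 2 `CCCn1cnc2c(N(C)C)ncnc21` gives 14 mg/kg. Compound 3 `c1nc(NC2CC2)c2ncn(CC3CCCC3)c2n1` gives 15 mg/kg, the highest of the three numbers, but its gap to compound 2 and its gap to compound 1 both fall within the scatter, so the three compounds are not separated on this read-out.

For the measured compounds named here, no step between two measured compounds that differ in one place is available, so the size of any single change has not been read in this assay. Compound 4 `CCCn1cnc2c(NC3CC3)ncnc21` is not yet measured. It differs from compound 3 in one place: ethyl in place of cyclopentyl on a saturated chain carbon bound to an aromatic nitrogen. Compound 2 also carries a propyl chain, and its number sits within the scatter of the number for compound 3, which is the only hint on this kind of change.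

The step from compound 3 to compound 4 is expected to be a 1.1-fold lower number from compound 3 to compound 4 (0.03 log units; within the scatter), that is, no movement beyond the scatter in either direction. Compound 4 is estimated at 14 mg/kg, with a range from 7 mg/kg to 28 mg/kg, because compound 2 gives 14 mg/kg and the measured compounds all lie close together.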

Compound 4, dose for half-maximal effect: 6 mg/kg
Estimate against measurement, compound 4: 2.3-fold (0.37 log units) above, and the stated range ends above it.
By their numbers in this assay, from the lowest: compound 4; then compounds 1, 2 and 3 (each within the scatter of the next).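

In this assay, for the compounds shown here, ethyl in place of cyclopentyl on a saturated chain carbon bound to an aromatic nitrogen gives a 2.5-fold lower number from compound 3 to compound 4 (0.40 log units; beyond the scatter), so this place responds to a change of group, which the earlier compounds could not show with no single-place step among them. Cyclopropylamino in place of dimethylamino on an aromatic carbon, with the propyl chain kept, gives a 2.3-fold lower number from compound 2 to compound 4 (0.37 log units; beyond the scatter), so the number for compound 2 did not speak for every compound with a propyl chain, and the amino group also matters on this read-out. The data on hand give no reason for either step.

From the compounds shown here alone, both steps end at compound 4, so neither change has been read on a second pair of compounds, and it remains open whether either step keeps its size with the other group in place. Going by these compounds, how far the trend from cyclopentylmethyl to propyl extends also remains open, since a shorter ethyl chain, a longer butyl chain or a chain bearing an amine could each sit at this place.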